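Expecting the Outcome of One Group Swap

The compounds below may be only part of what the source reports. "The series", "measured", "known", "first", "only" and "open" are said of these compounds alone.

compound 1 `C/C(=N\NC(=O)COc1cccc2ccccc12)c1ccc(C#N)cc1Br` gives 3.61
compound 2 `O=C(COc1cccc2ccccc12)N/N=C/c1ccccc1` gives 4.02

Both values come from a physicochemical assay for lipophilicity, measured as octanol-water partition; on this read-out higher numbers stand for higher lipophilicity and lower numbers for lower lipophilicity. Compound 1 is the lower of the two, and compound 2 stands above it by more than the usual scatter. Compound 3 `C/C(=N\NC(=O)COc1cccc2ccccc12)c1ccc(O)cc1` has not yet been measured. It differs from compound 1 in one place: 4-hydroxyphenyl in place of 2-bromo-4-cyanophenyl on a carbon with a double bond to nitrogen. In words, this is 4-hydroxyphenyl in place of 2-bromo-4-cyanophenyl on a carbon with a double bond to nitrogen. For the measured compounds named here, no two measured compounds differ in just one place, so no measured step can guide this expectation, and it remains rough. The entering group has fewer heavy atoms and brings a hydrogen-bond donor, and on that basis a moderate downward change is expected. The estimated change is a number 0.41 log units lower from compound 1 to compound 3 (beyond the scatter), which would lie beyond the scatter. For compound 3 the estimated value is 3.2, with a range from 2.7 to 3.7.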

Compound 3, partition coefficient: 4.44
Compound 3: the middle estimate sits 1.24 log units below what was measured; measured number outside the range, above it.
By their numbers in this assay, from the lowest: compound 1; then compound 2; then compound 3.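

On a carbon with a double bond to nitrogen, this assay shows a clear response to one change: placing 4-hydroxyphenyl where 2-bromo-4-cyanophenyl stood gives a number 0.83 log units higher from compound 1 to compound 3 (beyond the scatter). For the compounds shown here, this is the first comparison here in which only one place differs, and the number rises even though the entering group has fewer heavy atoms and brings a hydrogen-bond donor, so those two counts do not fix the direction at this position. Nothing available explains the rise.

Going by these compounds, this single swap removes the bromine and the nitrile and adds the hydroxyl all at once, so the share of each remains open. On these data alone, whether a group such as 4-methoxyphenyl or 4-aminophenyl at the same place would move the number in the same direction also remains unknown.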